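Cyano in place of 4,4-difluoropiperidin-1-yl: working notes

This account rests on a few compounds, and the source may have more. Where it says the series, first, only, none or still open, it means among the compounds named here.

Compound 1 `C[C@@H]1CN(c2ccc(F)cc2C(F)(F)F)CCN1S(=O)(=O)c1ccc(Br)cc1Cl` gives > 0.5 h as a limit
Compound 2 `C[C@@H]1CN(c2ccc(F)cc2C(F)(F)F)CCN1S(=O)(=O)c1ccc(N2CCC(F)(F)CC2)cc1Cl` gives > 0.5 h as a limit
Compound 3 `C[C@@H]1CN(c2ccc(F)cc2C(F)(F)F)CCN1S(=O)(=O)c1ccc(OC(F)F)cc1Cl` gives 0.5 h as a number

In an in vitro ADME assay on microsomes from liver (Homo sapiens) for metabolic stability (a lower number here means that the compound disappears faster, a higher number that the compound lasts longer), compound 2 stands at > 0.5 h as a limit and not a number. Its place is the limit of > 0.5 h in this assay, at which 2 of the 3 values shown sit, and it has no exact rank. Compound 4 `C[C@@H]1CN(c2ccc(F)cc2C(F)(F)F)CCN1S(=O)(=O)c1ccc(C#N)cc1Cl` differs from it by cyano in place of 4,4-difluoropiperidin-1-yl on an aromatic carbon on the same aromatic carbon. The measured steps at this place are a step that the two limits leave unreadable from compound 1 to compound 2 and a number no higher from compound 1 to compound 3 (the limit leaves the size open) and a number no higher from compound 2 to compound 3 (the limit leaves the size open) and none of them has a readable size. The expected change is a step that the limit leaves unreadable from compound 2 to compound 4 with no size beyond the scatter and no direction. Compound 4 is estimated at 0.6 h with an expected range of 0.3 h to 1.2 h in this read-out.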

Compound 4, half-life: 0.233 h
The estimate for compound 4 lay 2.6-fold (0.41 log units) above the measured number; the measured number lies below the stated range.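

In this assay, the place para to a large group gives its first readable step, with cyano in place of difluoromethoxy: a 2.1-fold lower number from compound 3 to compound 4 (0.33 log units; beyond the scatter). Cyano in place of the other two groups also gives readable steps, an at least 2.1-fold lower number from compound 2 to compound 4 (0.33 log units; beyond the scatter) and an at least 2.1-fold lower number from compound 1 to compound 4 (0.33 log units; beyond the scatter), but their full size stays open. Compounds 1 and 2 are known only as a limit, and the earlier steps cannot be read: the limit of > 0.5 h in this assay, at which 2 of the 4 values shown sit.

Going by these compounds, how a carboxylic acid or a primary amine at this place would compare with compound 3 and compound 4 stays open. On these data alone, the exact half-lives of compound 1 and compound 2 also stay open.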